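Carbamoyl to ethyl: leaving the assay limit?

The compounds below may be only part of what the source reports. "The series", "measured", "known", "first", "only" and "open" are said of these compounds alone.

Compound 1 `COc1cc(OC)cc(C(=CC(N)=O)c2ccc(OC)c(OC)c2)c1`: > 10000 nM (a limit)
Compound 2 `CCOc1cc(C(=CC#N)c2cccc(OC)c2)ccc1OC`: 450 nM
Compound 3 `CCOc1cc(C(=CC#N)c2ccc(S(C)(=O)=O)cc2)ccc1OC`: > 10000 nM (a limit)

In a functional assay on HCT-116 cells (Homo sapiens) for cytotoxicity, read by scintillation counting and thymidine incorporation, with a stated time of 72 h (a lower number here means a stronger inhibitor, a higher number a weaker inhibitor), compound 1 reads > 10000 nM, which is a limit of the assay and not a number. Compound 1 therefore stands at the limit of > 10000 nM in this assay, at which 2 of the 3 values shown sit, with no exact potency to start from. Compound 2 is the only one of the three that gives a measured number, 450 nM.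

The next compound to be measured, compound 4 `CCC=C(c1cc(OC)cc(OC)c1)c1ccc(OC)c(OC)c1`, keeps the core of compound 1 but has ethyl in place of carbamoyl on a double-bonded chain carbon bound to a double-bonded chain carbon. Among the compounds with values here, no measured pair shows this change, so its size must be estimated. A modest gain in inhibition is expected, and it rests on compound 2, which lacks carbamoyl and reaches 450 nM. Compound 3 goes against this: it also lacks carbamoyl, yet it gives > 10000 nM, again a limit. The expected step is an at least 2.5-fold lower number from compound 1 to compound 4 (0.39 log units; beyond the scatter), towards stronger inhibition, although the result may remain at the limit. The estimated value for compound 4 is 4000 nM, with an expected range of 400 nM to 10000 nM.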

Compound 4, half-maximal inhibitory concentration: > 10000 nM
Compound 4: only a limit was reported (the forecaster's own chance of this, stated with the estimate: 45%); middle value at least 2.5-fold (0.39 log units) from the limit.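

In this assay compound 4 gives > 10000 nM, which is a limit of the assay and not a number. Compound 1 also sits at a limit, so no step between compound 1 and compound 4 can be read: the limit of > 10000 nM in this assay, at which 3 of the 4 values shown sit.

The compounds shown leave open whether ethyl in place of carbamoyl changes inhibition at all, and in which direction.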